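Enlarging the ring on the chain carbon

The compounds below may be only part of what the source reports. "The series", "measured", "known", "first", "only" and "open" are said of these compounds alone.

Compound 1 `CCOC(=O)C1=C(Nc2ccccc2)S/C(=C\c2ccc(OC)cc2)C1=O` gives 32.9% in a functional assay on JAR cells (Homo sapiens) for inhibition, read by MTT assay, with a stated time of 72 h, tested at 10 uM; a lower number here means less inhibition, a higher number more inhibition at the concentration tested (going by the name of the read-out).
Compound 2 `CCOC(=O)C1=C(Nc2ccccc2)S/C(=C\c2cccc(C(=O)O)c2)C1=O` gives 50.6%.
Compound 3 `CCOC(=O)C1=C(Nc2ccccc2)S/C(=C\c2cc[nH]c2)C1=O` gives 19.5%.

Compound 3 stands lowest of the three: a number 13.4 percentage points lower from compound 1 to compound 3 (beyond the scatter) and a number 31.1 percentage points lower from compound 2 to compound 3 (beyond the scatter). Compound 4 `CCOC(=O)C1=C(Nc2ccccc2)S/C(=C\c2cc3cccnc3[nH]2)C1=O` differs from compound 3 in one place: a group of 9 heavy atoms (7 carbon, 2 nitrogen; one five-membered aromatic ring with 1 hetero atom, one six-membered aromatic ring with 1 hetero atom) in place of a group of 5 heavy atoms (4 carbon, 1 nitrogen; one five-membered aromatic ring with 1 hetero atom), on a double-bonded chain carbon bound to a double-bonded ring carbon. Going by the values given here, both measured steps into compound 3 ran downward when 4-methoxyphenyl or 3-carboxyphenyl gave way to 1H-pyrrol-3-yl; compound 4 adds a six-membered aromatic ring with 1 hetero atom onto that five-membered ring, so a rise beyond the scatter is expected, although no measured step tests this exact change. Compound 4 is therefore estimated at 32%, between 16% and 50%, an expected step of a number 12.5 percentage points higher from compound 3 to compound 4 (beyond the scatter).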

Compound 4, a percentage reported as inhibition, at one concentration (the size of the read-out at that concentration, not a potency): 54.3%
Estimate against measurement, compound 4: 22.3 percentage points below, and the stated range ends below it.
By their numbers in this assay, from the lowest: compound 3; then compound 1; then compounds 2 and 4 (each within the scatter of the next).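

In this assay the step of a number 34.8 percentage points higher from compound 3 to compound 4 (beyond the scatter) shows that the low number of the lone five-membered ring does not hold once a six-membered aromatic ring with 1 hetero atom is added to it. The same group gives a number 21.4 percentage points higher from compound 1 to compound 4 (beyond the scatter) and a number 3.7 percentage points higher from compound 2 to compound 4 (within the scatter) so at this position a group without a carboxylic acid reaches the level of compound 2.

Still open, from the compounds shown here alone, is whether the nitrogen of the six-membered ring matters, which an indol-2-yl group, with only carbon in that ring, would test. Nothing measured here gives a cause for these steps.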